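A few compounds are considered here, and "the series" means these few. Any claim that something is new, unique, unknown or untested is made for them only; others in the source may bear on it.

Measured so far in a functional assay on MIA PaCa-2 cells (Homo sapiens) for inhibition, read by MTT assay, with a stated time of 48 h, tested at 10 uM; on this read-out lower numbers stand for less inhibition of growth and higher numbers for more inhibition of growth at the one concentration tested: compound 1 `O=C(/C=C/c1ccc(OCc2cn(Cc3cccc(Br)c3)nn2)cc1)c1ccc(Br)cc1` gives 43%; compound 2 `O=C(/C=C/c1ccc(OCc2cn(Cc3ccccc3F)nn2)cc1)c1ccc(Br)cc1` gives 28%.

Compound 2 stands lowest of the two numbers in this assay; its nearest neighbour is compound 1, the step being a number 15 percentage points lower from compound 1 to compound 2 (beyond the scatter). Compound 3 `O=C(/C=C/c1ccc(OCc2cn(Cc3cccc(F)c3)nn2)cc1)c1ccc(Br)cc1` differs from compound 2 by 3-fluorophenyl in place of 2-fluorophenyl on a saturated chain carbon bound to an aromatic nitrogen. For the measured compounds named here, only one measured step bears on this change, a number 15 percentage points lower from compound 1 to compound 2 (beyond the scatter), and it alters the halogen as well as its place, so it guides the present move only loosely. A small rise beyond the scatter is therefore expected in this assay, a number 8 percentage points higher from compound 2 to compound 3 (within the scatter). For compound 3 the estimate is 36%, with a range from 22% to 50%.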

Compound 3, percent growth inhibition at one concentration: 34%
Estimate against measurement, compound 3: 2 percentage points above, and the stated range covers the measured number.
By their numbers in this assay, from the lowest: compounds 2, 3 and 1 (each within the scatter of the next, the first and the last beyond it).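

In this assay, 3-fluorophenyl in place of 2-fluorophenyl gives a number 6 percentage points higher from compound 2 to compound 3 (within the scatter), so the place of the fluorine on this ring has no clear effect here. Fluoro in place of bromo at the same ring place gives a number 9 percentage points lower from compound 1 to compound 3 (within the scatter), so neither single change clearly moves the number, although the two together gave a number 15 percentage points lower from compound 1 to compound 2 (beyond the scatter). No measurement at hand gives a reason for these numbers.

Still open, from the compounds shown here alone, is how 2-bromophenyl would compare, which would test the two changes in the other order. Also open, going by these compounds, is whether a methoxy or amino group on this ring would read differently.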